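The source may report more compounds than this note shows. Statements on the series, on what has been measured and on what is new or still open speak of the compounds shown alone.

In an assay on HEK293 cells for positive allosteric modulation of metabotropic glutamate receptor 2 (Rattus norvegicus), read by thallium flux (on this read-out higher numbers stand for an effect only at larger amounts of compound and lower numbers for an effect already at smaller amounts), compound 2 `O=C(O)c1ccc(-c2cccc(COc3ccc4c(c3)CN(C3CCCC3)C4=O)c2)c(Cl)c1` gives 110 nM, the lowest of the three numbers measured. Compound 1 `O=C(O)c1cc(-c2cccc(COc3ccc4c(=O)n(C5CCC5)sc4c3)c2)ccc1Cl` gives 580 nM and compound 3 `Cc1ccc(C(=O)O)cc1-c1cccc(COc2ccc3c(=O)n(C4CCCC4)sc3c2)c1` gives 740 nM in this assay, both well beyond the scatter above compound 2. Compound 4 `O=C1c2ccc(OCc3cccc(-c4ccccc4)c3)cc2CN1C1CCCC1` has not yet been measured in this assay. It differs from compound 2 by phenyl in place of 4-carboxy-2-chlorophenyl on an aromatic carbon. No measured pair in this set makes the same change, so the 4-carboxy-2-chlorophenyl group has no shown step of its own. The step is expected to be a sizeable loss, with the number for compound 4 rising by a 27-fold higher number from compound 2 to compound 4 (1.44 log units; beyond the scatter) in this assay. Compound 4 is therefore estimated to give about 3000 nM, with a plausible range from 500 nM to 20000 nM.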

Compound 4, half-maximal effective concentration: > 5000 nM
Compound 4 was reported as a limit (the forecaster's own chance of this, stated with the estimate: 25%); at least 1.6-fold (0.22 log units) between middle value and limit.
By their numbers in this assay, from the lowest: compound 2; then compounds 1 and 3 (each within the scatter of the next). At a limit, above all of these: compound 4.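

In this assay this position now has its first readable step, an at least 45-fold higher number from compound 2 to compound 4 (1.65 log units; beyond the scatter) for phenyl in place of 4-carboxy-2-chlorophenyl. Compound 4 gives > 5000 nM as a limit of the assay, not a number. Among the compounds shown here, the full size of the step therefore stays unknown, but plain phenyl on this aromatic carbon does not keep the low number of compound 2, which the earlier compounds could not show.

Which part of the 4-carboxy-2-chlorophenyl group carries this step, the carboxylic acid or the chlorine, remains open. Also open, on these data alone, is whether a tetrazole or a primary amide could stand in for the carboxylic acid.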